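From Butyl to Methoxyphenyl on the Shared Core

The source may report more compounds than this note shows. Statements on the series, on what has been measured and on what is new or still open speak of the compounds shown alone.

Of the compounds shown here, three built on one shared core have been tested in a functional assay on HeLa cells (Homo sapiens) for antiproliferative activity, read by MTT assay, with a stated time of 72 h; a lower number here means a stronger inhibitor, a higher number a weaker inhibitor. Compound 1 `O=C1O[C@H]([C@@H](O)Cn2cc(-c3cccc(O)c3)nn2)C(OCc2ccccc2)=C1OCc1ccccc1` gives 39300 nM. Compound 2 `CCCCc1cn(C[C@H](O)[C@H]2OC(=O)C(OCc3ccccc3)=C2OCc2ccccc2)nn1` gives 18100 nM, which is the lowest of the two numbers shown. Compound 3 `CC(C)(C)OC(=O)N1CCN(C(=S)SCc2cn(C[C@H](O)[C@H]3OC(=O)C(OCc4ccccc4)=C3OCc3ccccc3)nn2)CC1` reaches only a limit of the assay, > 100000 nM. For the measured compounds named here, the single step that can be traced, a 2.2-fold lower number from compound 1 to compound 2 (0.34 log units; beyond the scatter), shows the butyl group giving the lower number relative to the hydroxyphenyl group.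

Compound 4 `COc1ccccc1-c1cn(C[C@H](O)[C@H]2OC(=O)C(OCc3ccccc3)=C2OCc2ccccc2)nn1` carries the change (2-methoxyphenyl in place of butyl on an aromatic carbon). The measured step from compound 1 to compound 2 bears on this in reverse: an aromatic ring in place of butyl went with a modest rise in the number, and compound 4 again puts an aromatic ring in that place. A rise of about that size in this assay is therefore expected. Compound 4 is estimated at 35000 nM, with a range from 12000 nM to 100000 nM. The expected step of a 1.9-fold higher number from compound 2 to compound 4 (0.29 log units; within the scatter) is a modest weakening, with some chance that only a limit is reported.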

Compound 4, half-maximal inhibitory concentration: > 100000 nM
Compound 4: no number, only a limit; the forecaster's own chance of this, stated with the estimate: 20%; middle value at least 2.8-fold (0.45 log units) away from the limit.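

In this assay, compound 4 gives only a limit of the assay, not a number: the limit of > 100000 nM in this assay, at which 2 of the 4 values shown sit.

Even so, placing 2-methoxyphenyl instead of butyl on this aromatic carbon gives an at least 5.5-fold higher number from compound 2 to compound 4 (0.74 log units; beyond the scatter), a larger change than the earlier step between the butyl and 3-hydroxyphenyl groups could show. The change from 3-hydroxyphenyl to 2-methoxyphenyl gives an at least 2.5-fold higher number from compound 1 to compound 4 (0.40 log units; beyond the scatter), so the two aromatic groups are not interchangeable at this position, and having an aromatic ring there does not by itself set the number.

The compounds shown leave open whether the methoxy group or its location on the ring accounts for this difference, as the two aromatic groups differ in both. They also leave open whether a plain phenyl ring, a longer chain or an amine at this carbon would give a lower number than compound 2.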